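Amide Chain Change Carried onto a Pyridinyl Analogue

This account rests on a few compounds, and the source may have more. Where it says the series, first, only, none or still open, it means among the compounds named here.

Compound 1 `CCC/C=C/C(=O)Nc1cccc(Oc2nc(Nc3cccc(OC)c3)nc3c2CSCC3)c1` — 11800 nM
Compound 2 `COc1cccc(Nc2nc3c(c(Oc4cccc(NC(=O)C=C(C)C)c4)n2)CSCC3)c1` — 19800 nM
Compound 3 `CCC/C=C/C(=O)Nc1cccc(Oc2nc(Nc3ccc(OC)nc3)nc3c2CSCC3)c1` — 10800 nM

Three compounds were tested in a functional assay on A549 cells (Homo sapiens) for antiproliferative activity, read by MTT assay, with a stated time of 72 h; on this read-out higher numbers stand for weaker inhibition and lower numbers for stronger inhibition. Compound 1 gives 11800 nM, compound 2 gives 19800 nM and compound 3 gives 10800 nM in this assay. All three share a core and differ in two places.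

The first difference is in the amide chain: 2-methylprop-1-en-1-yl in place of pent-1-en-1-yl on a carbonyl carbon. This change made the step of a 1.7-fold higher number from compound 1 to compound 2 (0.22 log units; within the scatter). The second difference is in the group on the aromatic amine nitrogen: 6-methoxypyridin-3-yl in place of 3-methoxyphenyl on a nitrogen on an aromatic ring. This change made the step of a 1.1-fold lower number from compound 1 to compound 3 (0.04 log units; within the scatter).

Compound 4 `COc1ccc(Nc2nc3c(c(Oc4cccc(NC(=O)C=C(C)C)c4)n2)CSCC3)cn1` has not yet been measured. It differs from compound 3 as follows: 2-methylprop-1-en-1-yl in place of pent-1-en-1-yl on a carbonyl carbon. Within the data shown here, this is the same change as the one from compound 1 to compound 2, and it sits in the same place, on a carbonyl carbon whose other neighbour is an amide-type nitrogen. The only other difference between the two pairs is the core, as described by 6-methoxypyridin-3-yl in place of 3-methoxyphenyl on a nitrogen on an aromatic ring.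

With one prior example, the author expects the step of a 1.7-fold higher number from compound 3 to compound 4 (0.22 log units; within the scatter) to run close to the earlier step because a 1.7-fold higher number from compound 1 to compound 2 (0.22 log units; within the scatter) carries the same change in the same place. Compound 4 is therefore expected to give about 18000 nM in this assay. Allowing for the uncertainty of a single prior example, the estimate for compound 4 is expected to fall between 9000 nM and 36000 nM.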

Compound 4, half-maximal inhibitory concentration: 16800 nM
Compound 4: the middle estimate sits 1.1-fold (0.03 log units) above what was measured; low and high end bracket the measured number.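

In this assay, 2-methylprop-1-en-1-yl in place of pent-1-en-1-yl on the carbonyl carbon gives a 1.6-fold higher number from compound 3 to compound 4 (0.19 log units; within the scatter), and this step agrees with its earlier counterpart: the same change on two cores in this assay, a 1.7-fold higher number (0.22 log units; within the scatter) from compound 1 to compound 2 and a 1.6-fold higher number (0.19 log units; within the scatter) from compound 3 to compound 4, 1.1-fold (0.03 log units) apart, within the scatter of two such steps. Read the other way round, 6-methoxypyridin-3-yl in place of 3-methoxyphenyl on the nitrogen gives a 1.2-fold lower number from compound 2 to compound 4 (0.07 log units; within the scatter) with the 2-methylprop-1-en-1-yl chain in place, and this step also agrees with its counterpart on the pent-1-en-1-yl chain: the same change on two cores in this assay, a 1.1-fold lower number (0.04 log units; within the scatter) from compound 1 to compound 3 and a 1.2-fold lower number (0.07 log units; within the scatter) from compound 2 to compound 4, 1.1-fold (0.03 log units) apart, within the scatter of two such steps. The four compounds therefore show that neither change produced a step beyond the scatter on either core, but with every step inside the scatter they do not show that either change has a real effect that carries from core to core, and a single pair of cores in one cell assay cannot establish a rule for the series.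

From the compounds shown here alone, it remains open whether the same agreement would hold for a change large enough to stand clear of the scatter, such as a longer chain or a chain ending in an amine on the carbonyl carbon. Also open, going by these compounds, is whether a saturated chain in place of the pent-1-en-1-yl group, or a carboxylic acid on the group on the nitrogen, would carry across these cores in the same way.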